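Aryl variation on the core nitrogen: expectation for compound 4

The source may report more compounds than this note shows. Statements on the series, on what has been measured and on what is new or still open speak of the compounds shown alone.

Measured compounds:
compound 1 `CCc1ccc(-n2nc(-c3ccc(C(F)(F)F)cc3O)nc2-c2ccccc2O)cc1` gives 64.4%
compound 2 `Oc1cc(C(F)(F)F)ccc1-c1nc(-c2ccccc2O)n(-c2ccc(Cl)cc2)n1` gives 68%
compound 3 `Oc1cc(C(F)(F)F)ccc1-c1nc(-c2ccccc2O)n(-c2ccc(C(F)(F)F)cc2)n1` gives 70.7%

All three values come from a functional assay on PC-12 cells (Rattus norvegicus) for cytotoxicity, read by MTT assay, with stated times of 2 h and 24 h, tested at 1 uM; on this read-out lower numbers stand for a weaker effect and higher numbers for a stronger effect at the one concentration tested. Compound 3 holds the highest of the three numbers, but its nearest neighbour is compound 2, which lies within the scatter of it, and even compound 1 lies within the scatter, so no order among the three can be claimed. The three steps that alter the group on the aromatic nitrogen of the shared core are a number 3.6 percentage points higher from compound 1 to compound 2 (within the scatter), a number 6.3 percentage points higher from compound 1 to compound 3 (within the scatter) and a number 2.7 percentage points higher from compound 2 to compound 3 (within the scatter), each within the scatter.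

Compound 4 `Oc1cc(C(F)(F)F)ccc1-c1nc(-c2ccccc2O)n(-c2cccc(F)c2)n1` is not yet measured. Its change from compound 3: 3-fluorophenyl in place of 4-(trifluoromethyl)phenyl on an aromatic nitrogen. This is again a swap of the aryl on the aromatic nitrogen, the same place varied in the three measured steps, all of which stayed within the scatter. The expectation for this assay is therefore a step of a number 4.7 percentage points lower from compound 3 to compound 4 (within the scatter), that is, none beyond the scatter. Compound 4 is estimated at 66%, with a range from 55% to 77%.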

Compound 4, a percentage reported as activity, at one concentration (the size of the read-out at that concentration, not a potency): 67.2%
Estimate against measurement, compound 4: 1.2 percentage points below; low and high end bracket the measured number.
By their numbers in this assay, from the lowest: compounds 1, 4, 2 and 3 (each within the scatter of the next).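

In this assay the swap to 3-fluorophenyl on the aromatic nitrogen gives a number 3.5 percentage points lower from compound 3 to compound 4 (within the scatter) and a number 0.8 percentage points lower from compound 2 to compound 4 (within the scatter) and a number 2.8 percentage points higher from compound 1 to compound 4 (within the scatter) so that no order can be claimed among the four aryl groups. New here is an aryl group whose name carries its substituent at the 3-position, and also a smaller entering group: 3-fluorophenyl has fewer heavy atoms than 4-(trifluoromethyl)phenyl, yet the two numbers stay within the scatter of each other. No accompanying measurement offers an explanation for this result.

On these data alone, whether the same holds for an aryl group bearing an amine or a carboxylic acid, or for a longer chain on the aromatic nitrogen in place of an aryl group, stays open. As far as these compounds go, the two hydroxyphenyl groups are the same in all four compounds, so what they contribute to this read-out also stays open.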